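The compounds below may be only part of what the source reports. "The series", "measured", "known", "first", "only" and "open" are said of these compounds alone.

Compound 1 `CC(C)c1ncn2c(S)nncc12` gives a limit in a functional assay for inhibition, with Homo sapiens as the target (a higher number here means a weaker inhibitor, a lower number a stronger inhibitor), namely > 48000 nM. Compound 2 `CSc1nncc2c(C(C)C)ncn12` likewise gives only a limit there, > 48000 nM. Compound 3 `C=CCn1nc(C)c2c(C)nc(CCC)n2c1=O` gives 69000 nM; > 48000 nM (2 entries).

Compound 2 therefore stands on a limit of the assay and not on a number. Among the measured compounds shown here, the one step among the measured compounds, methyl in place of hydrogen on a sulfur from compound 1 to compound 2, a step that the two limits leave unreadable from compound 1 to compound 2, cannot be read, since both ends are limits. For the measured compounds named here, the only numbered value comes from compound 3, and the several entries of compound 3 in this assay, 69000 nM; > 48000 nM (2 entries) shows that even that compound sits at or beyond the edge of what the assay resolves; the limit of > 48000 nM in this assay, at which 2 of the 3 values shown sit, shows where most of the measured values rest.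

Compound 4 `CCCc1ncn2c(SC)nncc12` differs from compound 2 by propyl in place of isopropyl on an aromatic carbon. Going by the values given here, no measured step touches this change, and the single readable step in this assay is unreadable. Among the compounds with values here, nothing among the measured compounds points to a shift beyond the scatter in either direction, so compound 4 is expected to behave like compound 2, with the step from compound 2 to compound 4 estimated at a step that the limit leaves unreadable from compound 2 to compound 4. For compound 4 the estimate is 80000 nM, with a range from 30000 nM to 300000 nM, and most likely the assay will again report only a limit.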

Compound 4, half-maximal inhibitory concentration: > 48000 nM
Compound 4: a limit, no number (the forecaster's own chance of this, stated with the estimate: 70%); the middle value does not contradict the limit.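

In this assay compound 4 gives > 48000 nM, a limit of the assay and not a number. Compound 2 also rests on a limit, so the step between compound 2 and compound 4 cannot be read. The compounds shown leave open whether propyl in place of isopropyl on an aromatic carbon changes inhibition at all.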